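The source may report more compounds than this note shows. Statements on the series, on what has been measured and on what is new or still open speak of the compounds shown alone.

Three compounds share one core in which a ring nitrogen carries either a carbonyl or a sulfonyl group. Compound 1 `CN1CCN(c2ccc(C3=NN(C(=O)c4ccc(C(F)(F)F)cc4)C(c4ccc(N(C)C)cc4)C3)cc2)CC1` carries (4-(trifluoromethyl)phenyl)carbonyl there, and in a functional assay on NCI-H1975 cells (Homo sapiens) for inhibition, read by sulforhodamine B assay, tested at 10 uM (a higher number here means more inhibition at the concentration tested (going by the name of the read-out), a lower number less inhibition), compound 1 gives 93.2%, the highest of the three numbers. Compound 2 `Cc1ccc(S(=O)(=O)N2N=C(c3ccc(N4CCN(C)CC4)cc3)CC2c2ccc(N(C)C)cc2)cc1` gives 38.1% in this assay, and compound 3 `CN1CCN(c2ccc(C3=NN(S(=O)(=O)c4ccc(Br)cc4)C(c4ccc(N(C)C)cc4)C3)cc2)CC1` gives 70.8%. The measured steps are a number 55.1 percentage points lower from compound 1 to compound 2 (beyond the scatter), a number 22.4 percentage points lower from compound 1 to compound 3 (beyond the scatter) and a number 32.7 percentage points higher from compound 2 to compound 3 (beyond the scatter); each of them alters only the group on the ring nitrogen and leaves the rest of the molecule untouched.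

Compound 4 `CN(C)c1ccc(C2CC(c3ccc(-n4cncn4)cc3)=NN2C(=O)c2ccc(C(F)(F)F)cc2)cc1` keeps the carbonyl group of compound 1 and changes a different place: 1H-1,2,4-triazol-1-yl in place of 4-methylpiperazin-1-yl on an aromatic carbon. Among the compounds with values here, none of the measured steps touches this position, so they give no direct guide to the size or direction of the step; they show only that the shared core responds to structural change with steps of modest and of large size. Compound 1 stands at 93.2% in this assay. Compound 4 is expected to give a number somewhat lower than that of compound 1, estimated at 70% within a range from 35% to 95%. The expected step is a number 23.2 percentage points lower from compound 1 to compound 4 (beyond the scatter).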

Compound 4, a percentage reported as inhibition, at one concentration (the size of the read-out at that concentration, not a potency): 11.5%
Beside the measured number, compound 4's estimate is 58.5 percentage points above it, and the stated range ends above it.
By their numbers in this assay, from the lowest: compound 4; then compound 2; then compound 3; then compound 1.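

The place on the aromatic carbon that holds 4-methylpiperazin-1-yl in compound 1 proves highly sensitive. In this assay, 1H-1,2,4-triazol-1-yl in place of that group gives a number 81.7 percentage points lower from compound 1 to compound 4 (beyond the scatter), a step greater in size than the largest one seen at the ring nitrogen, a number 55.1 percentage points lower from compound 1 to compound 2 (beyond the scatter). Compound 4 keeps the (4-(trifluoromethyl)phenyl)carbonyl group of compound 1, so that group does not by itself secure a high number once this other place changes, and nothing at hand accounts for the size of the step.

This single exchange alters the ring size, the aromatic character and the number of ring nitrogens all at once, so the compounds shown leave open which of these differences goes with the step, a question that a morpholin-4-yl, piperidin-1-yl or unsubstituted piperazin-1-yl group at the same place could help to separate. They also leave open whether 1H-1,2,4-triazol-1-yl would give a step of similar size and direction on a compound with a sulfonyl group on the ring nitrogen, such as compound 3.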